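The compounds below may be only part of what the source reports. "The series", "measured", "known", "first", "only" and "open" are said of these compounds alone.

In a functional assay on IMR-32 cells (Homo sapiens) for antiproliferative activity, read by MTT assay (a lower number here means a stronger inhibitor, a higher number a weaker inhibitor), the measured compounds are these
compound 1 `CC1(C)CCc2cc(C(=O)/C=C/c3ccc(OCc4cn(-c5ccc(Br)cc5)nn4)cc3)c(O)cc2O1`: 69400 nM
compound 2 `CC(=O)c1ccc(-n2cc(COc3ccc(/C=C/C(=O)c4cc5c(cc4O)OC(C)(C)CC5)cc3)nn2)cc1`: "not active" (no number reported)
compound 3 `CC1(C)CCc2c(ccc(C(=O)/C=C/c3ccc(OCc4cn(-c5ccc(Cl)cc5)nn4)cc3)c2O)O1`: "not active" (no number reported)

Compound 3 has no single number. Its entry reads "not active" (no number reported), and compound 2 is the only other entry of that kind. Compound 4 `CC1(C)CCc2c(ccc(C(=O)/C=C/c3ccc(OCc4cn(-c5ccc(Br)cc5)nn4)cc3)c2O)O1` has not yet been measured. The structural change is small, (bromo in place of chloro on an aromatic carbon), bromo in place of chloro on an aromatic carbon, para to a large group.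

With no number for compound 3, the size of this step cannot be measured. A swap of this kind is expected to bring no large step in either direction in this assay, so the likely outcome is a weak figure or again no number. The only figure to lean on comes from compound 1, which also carries the 4-bromophenyl group and gives 69400 nM in that assay. A single compound shows no pattern, so the expectation stays loose. Compound 4 is estimated at 60000 nM, in a range of 20000 nM to 150000 nM, should a number be reported at all.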

Compound 4, half-maximal inhibitory concentration: 117000 nM
For compound 4 the middle estimate is 2.0-fold (0.29 log units) below the measured one, within the range that was stated.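

For the compounds shown here, compound 3 has no single number, so no step from it to compound 4 can be read. The compounds shown leave open how far 4-bromophenyl in place of 4-chlorophenyl shifts antiproliferative activity on the shared core. Nothing measured here explains the figure for compound 4.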